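The source may hold more compounds than are shown below. What is called first, only, known or untested is meant among the compounds shown, and "the series" means these compounds.

Measured compounds:
compound 1 `COc1ccc2[nH]c(C(=O)N3CC(=O)N(Cc4ccccc4)[C@@H](CCN4CCC5(CC4)CC5)C3)cc2c1` — > 25000 nM
compound 2 `COc1cccc(CN2C(=O)CN(C(=O)c3cc4cc(OC)ccc4[nH]3)C[C@@H]2CCc2ccccc2)c1` — 5100 nM
compound 3 `COc1ccc2[nH]c(C(=O)N3CC(=O)N(Cc4cccc(OC(F)F)c4)[C@@H](CN4CCC(c5ccccn5)CC4)C3)cc2c1` — 11600 nM

In a physicochemical assay for solubility, read by spectrophotometry, in phosphate buffer, with a stated time of 2 h, at pH 7.4 (on this read-out higher numbers stand for higher solubility and lower numbers for lower solubility), compound 1 gives > 25000 nM, which is a limit of the assay and not a number; compound 1 therefore sits at the upper boundary of what this assay reports, as the limit of > 25000 nM in this assay, at which 1 of the 3 values shown sits, records. Compound 2 gives 5100 nM in this assay, and compound 3 gives 11600 nM; neither shares a single-point change with compound 1, so these two values only show where other members of the shared core have landed.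

The unmeasured compound 4 `COc1ccc2[nH]c(C(=O)N3CC(=O)N(Cc4ccccc4)[C@@H](CN4CCCc5ccccc54)C3)cc2c1` differs from compound 1 in one place: a group of 10 heavy atoms (9 carbon, 1 nitrogen; one six-membered non-aromatic ring with 1 hetero atom, one six-membered aromatic ring of carbon only) in place of a group of 9 heavy atoms (8 carbon, 1 nitrogen; one three-membered non-aromatic ring of carbon only, one six-membered non-aromatic ring with 1 hetero atom), on a saturated chain carbon bound to a saturated ring carbon. For the measured compounds named here, no measured step of this kind exists among the three compounds, so the direction must be judged from the wider spread. Compound 2 and compound 3 both fall well below the limit reached by compound 1, and compound 4 is expected to move in that direction too, with a step from compound 1 of an at least 3.1-fold lower number from compound 1 to compound 4 (0.49 log units; beyond the scatter) in this assay, beyond the usual scatter. The solubility of compound 4 in this assay is estimated at 8000 nM, in a range from 2500 nM to 25000 nM.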

Compound 4, solubility: 8500 nM
The estimate for compound 4 lay 1.1-fold (0.03 log units) below the measured number; measured number inside the range.
By their numbers in this assay, from the lowest: compounds 2, 4 and 3 (each within the scatter of the next, the first and the last beyond it). At a limit, above all of these: compound 1.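

For the compounds shown here, until now no two compounds differed in one place, so this is the first single change that can be read at this position, on a saturated chain carbon bound to a saturated ring carbon. In this assay, 1,2,3,4-tetrahydroquinolin-1-yl in place of the group holding a three-membered non-aromatic carbon ring and a six-membered non-aromatic ring gives an at least 2.9-fold lower number from compound 1 to compound 4 (0.46 log units; beyond the scatter). The two groups have the same hydrogen-bond donor and acceptor counts and no net charge, so the step arises with those counts unchanged, but its full size cannot be stated because compound 1 stands at a limit of the assay: the limit of > 25000 nM in this assay, at which 1 of the 4 values shown sits.

With a single exchange at this place, the compounds shown do not separate the part played by the six-membered aromatic ring of carbon only from that of the rest of the entering group. From the compounds shown here alone, how a morpholine, a primary amine or a carboxylic acid on a saturated chain carbon bound to a saturated ring carbon would read in this assay also remains open.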